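The source may report more compounds than this note shows. Statements on the series, on what has been measured and on what is new or still open speak of the compounds shown alone.

Measured so far:
- compound 1 `CN(C)CCCCOc1ccccc1/C=C/c1ccccc1Cl`: 50%
- compound 2 `CN(C)CCCCOc1ccccc1/C=C/c1cccc(Cl)c1`: 23.9%
- compound 3 `CN(C)CCCCOc1ccccc1/C=C/c1cccc(F)c1`: 12.5%

In a functional assay on the whole organism with Mus musculus as the target, at a dose of 50 mg/kg by the oral route (on this read-out lower numbers stand for less inhibition and higher numbers for more inhibition at the one dose given (going by the name of the read-out)), compound 1 stands highest of the three numbers. The nearest is compound 2, a number 26.1 percentage points lower from compound 1 to compound 2 (beyond the scatter); the furthest is compound 3, a number 37.5 percentage points lower from compound 1 to compound 3 (beyond the scatter). Between the two lower compounds, a number 11.4 percentage points lower from compound 2 to compound 3 (beyond the scatter).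

Compound 4 `COc1ccccc1/C=C/c1ccccc1OCCCCN(C)C` differs from compound 1 in one place: methoxy in place of chloro on an aromatic carbon. For the measured compounds named here, none of the measured steps exchanges chloro for methoxy at a ring carbon; the steps to compound 2 and compound 3 move the substituent or swap halogens, and each lowered the number from compound 1. They bear on compound 4 only loosely, so the expectation leans toward a drop beyond the scatter, of uncertain size. For compound 4 the estimate is 30%, range 10% to 55%, which means an expected a number 20 percentage points lower from compound 1 to compound 4 (beyond the scatter).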

Compound 4, a percentage reported as inhibition, in the whole organism at one dose (the size of the read-out at that dose, not a potency): 62.5%
Compound 4: middle estimate off by 32.5 percentage points, on the low side; the measured number lies above the stated range.
By their numbers in this assay, from the lowest: compound 3; then compound 2; then compound 1; then compound 4.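

In this assay, for the compounds shown here, methoxy on an aromatic carbon ortho to a large group is the only change from compound 1 that raises the number, with a number 12.5 percentage points higher from compound 1 to compound 4 (beyond the scatter), so this position takes a group other than chloro without loss. The 2-methoxyphenyl compound also stands well clear of both 3-halophenyl compounds, with a number 50 percentage points higher from compound 3 to compound 4 (beyond the scatter) and a number 38.6 percentage points higher from compound 2 to compound 4 (beyond the scatter), though each of these steps changes both the group and its place. Nothing available explains the gain.

On these data alone, whether ethoxy or hydroxy at this position would hold or extend the gain remains open. So does whether 3-methoxyphenyl would fall as 3-chlorophenyl does.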